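Ring-Closing the Amine on the Amide Side Chain

The compounds below may be only part of what the source reports. "The series", "measured", "known", "first", "only" and "open" are said of these compounds alone.

Of the three compounds measured in a functional assay on MCF7 cells (Homo sapiens) for antiproliferative activity, read by MTT assay, with a stated time of 48 h (a higher number here means a weaker inhibitor, a lower number a stronger inhibitor), compound 3 `COc1ccc(-c2cc3cc(OC)ccc3nc2Nc2ccc(NC(=O)CN(C)C)cc2)cc1` stands highest at 39500 nM. Compound 1 `CCN(CC)CC(=O)Nc1ccc(Nc2nc3cc(OC)ccc3cc2-c2ccc(OC)cc2)cc1` gives 17300 nM and compound 2 `COc1ccc(-c2cc3ccc(OC)cc3nc2Nc2ccc(NC(=O)CN3CCN(C)CC3)cc2)cc1` gives 2800 nM. Compound 4 `COc1ccc(-c2cc3cc(OC)ccc3nc2Nc2ccc(NC(=O)CN3CCCCC3)cc2)cc1` carries the change (piperidin-1-yl in place of dimethylamino on a saturated chain carbon bound to a carbonyl carbon). For the measured compounds named here, the only measured step that bears on it is a 6.2-fold lower number from compound 1 to compound 2 (0.79 log units; beyond the scatter), where an open-chain amine was likewise replaced by a ring amine on a different core, and that step was modest. Compound 4 is therefore expected to show a modest decrease, a 2.8-fold lower number from compound 3 to compound 4 (0.45 log units; beyond the scatter), since compound 3 at 39500 nM leaves room to improve. The estimate for compound 4 in this assay is 14000 nM, with a range from 5000 nM to 40000 nM.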

Compound 4, half-maximal inhibitory concentration: > 50000 nM
Compound 4: no number, only a limit; the forecaster's own chance of this, stated with the estimate: 5%; middle value at least 3.5-fold (0.55 log units) away from the limit.
By their numbers in this assay, from the lowest: compound 2; then compound 1; then compound 3. At a limit, above all of these: compound 4.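

Compound 4 gives no number in this assay, only a limit: the limit of > 50000 nM in this assay, at which 1 of the 4 values shown sits.

The step reads an at least 1.2-fold higher number from compound 3 to compound 4 (0.10 log units; that floor lies within the scatter), so piperidin-1-yl brought no gain over dimethylamino on this core, unlike the ring amine in a 6.2-fold lower number from compound 1 to compound 2 (0.79 log units; beyond the scatter). A ring amine in place of an open-chain amine therefore does not by itself lower the number: compound 2 goes with that change and compound 4 goes against it.

The compounds shown leave open how 4-methylpiperazin-1-yl would read on the core of compound 3, and how morpholin-4-yl would read on either core. On these data alone, how far compound 4 lies from compound 3 also stays open, as its floor lies within the scatter.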